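Swapping 4-fluorophenyl for benzyl on an amide-type nitrogen

The source may report more compounds than this note shows. Statements on the series, on what has been measured and on what is new or still open speak of the compounds shown alone.

- compound 1 `CC1=C(/C=C/C(C)=C/C=C/C(C)=C\C(=O)Nc2ccccc2)C(C)(C)CCC1n1ccnc1`: 8910 nM
- compound 2 `CC1=C(/C=C/C(C)=C/C=C/C(C)=C\C(=O)Nc2ccc(F)cc2)C(C)(C)CCC1n1ccnc1`: 30200 nM

In a functional assay on PC-3 cells (Homo sapiens) for inhibition, read by MTT assay (on this read-out higher numbers stand for weaker inhibition of growth and lower numbers for stronger inhibition of growth), compound 2 gives 30200 nM, the higher of the two numbers, which makes it the weaker growth inhibitor of the pair. The next compound to be tested, compound 3 `CC1=C(/C=C/C(C)=C/C=C/C(C)=C\C(=O)NCc2ccccc2)C(C)(C)CCC1n1ccnc1`, keeps the shared core but carries benzyl in place of 4-fluorophenyl on an amide-type nitrogen.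

Within the data shown here, only one measured step bears on this change: a 3.4-fold higher number from compound 1 to compound 2 (0.53 log units; beyond the scatter). That step, fluoro in place of hydrogen on an aromatic carbon, is modest. Compound 3 has no fluoro, and neither does compound 1, so the change may undo much of that step. Among the measured compounds shown here, no measured compound carries benzyl, however, so this reasoning is loose and the range must stay wide.

The expected change in this assay is a 2.7-fold lower number from compound 2 to compound 3 (0.44 log units; beyond the scatter), similar in size to the fluoro step but towards stronger inhibition of growth. For compound 3 the estimated value is 11000 nM, with an expected range from 3500 nM to 32000 nM.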

Compound 3, concentration for 50% growth inhibition: > 100000 nM
Compound 3: a limit, no number; the forecaster's own chance of this, stated with the estimate: 10%; middle value at least 9.0-fold (0.95 log units) from the limit.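

In this assay the reading for compound 3 is a limit of the assay and not a number: the limit of > 100000 nM in this assay, at which 1 of the 3 values shown sits. Benzyl in place of phenyl on the amide-type nitrogen gives an at least 11-fold higher number from compound 1 to compound 3 (1.05 log units; beyond the scatter), and benzyl in place of 4-fluorophenyl gives an at least 3.3-fold higher number from compound 2 to compound 3 (0.51 log units; beyond the scatter), so the group on this nitrogen can weaken growth inhibition well beyond what the fluoro step alone had shown. Neither compound 1 nor compound 3 carries fluoro, yet they stand far apart, which shows that the lack of fluoro does not by itself bring back the activity of compound 1, and that the ring attached directly to this nitrogen gives the lowest number of the three compounds shown.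

As far as these compounds go, both benzyl steps are minimum sizes, so how far compound 3 really lies from the other two stays unknown. From the compounds shown here alone, it is also open whether a longer chain such as 2-phenylethyl, a small group such as methyl, or a benzyl carrying its own fluoro would behave like benzyl or like phenyl on this nitrogen.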